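The compounds below may be only part of what the source reports. "The series", "measured", "known", "first", "only" and "open" are said of these compounds alone.

Measured in a physicochemical assay for solubility, read by nephelometry, measured as kinetic solubility, with a stated time of 30 min; on this read-out higher numbers stand for higher solubility and lower numbers for lower solubility:
- compound 1 `CC(C)(N)CCOc1ccc([C@H]2CC[C@]3(CC2)OOC2(O3)C3CC4CC(C3)CC2C4)cc1`: 50 ug/mL
- compound 2 `NC1CCN(S(=O)(=O)c2ccc([C@H]3CC[C@]4(CC3)OOC3(O4)C4CC5CC(C4)CC3C5)cc2)CC1`: 12.5 ug/mL
- compound 3 `CS(=O)(=O)N1CCN(CCCOc2ccc([C@H]3CC[C@]4(CC3)OOC3(O4)C4CC5CC(C4)CC3C5)cc2)CC1`: < 1.6 ug/mL, a limit of the assay and not a number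

Compound 1 gives 50 ug/mL, the higher of the two actual numbers. The nearest number comes with a 4.0-fold lower number from compound 1 to compound 2 (0.60 log units; beyond the scatter).

Compound 4 `N[C@H]1CC[C@@H](Oc2ccc([C@H]3CC[C@]4(CC3)OOC3(O4)C4CC5CC(C4)CC3C5)cc2)CC1` keeps the core of compound 1 and alters one group: 4-aminocyclohexyl in place of 3-amino-3-methylbutyl on an oxygen on an aromatic ring. An open chain thus gives way to one six-membered non-aromatic ring of carbon only, still joined through the oxygen on the aromatic ring.

Neither measured step makes this exact change, but both replace the same part of compound 1. The closer guide is a 4.0-fold lower number from compound 1 to compound 2 (0.60 log units; beyond the scatter), where (4-aminopiperidin-1-yl)sulfonyl also brings in a ring with an amino group. The other is an at least 31-fold lower number from compound 1 to compound 3 (1.49 log units; beyond the scatter), a wider change whose size rests on a limit. Both lead downward, so a modest fall is expected rather than a rise. The expected step is a 2.5-fold lower number from compound 1 to compound 4 (0.40 log units; beyond the scatter). For compound 4 the estimated value is 20 ug/mL, with an expected range of 6 ug/mL to 60 ug/mL.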

Compound 4, solubility: 25 ug/mL
The estimate for compound 4 lay 1.3-fold (0.10 log units) below the measured number; measured number inside the range.
By their numbers in this assay, from the lowest: compounds 2, 4 and 1 (each within the scatter of the next, the first and the last beyond it). At a limit, below all of these: compound 3.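

In this assay, the step from the open 3-amino-3-methylbutyl to the 4-aminocyclohexyl ring on this oxygen reads a 2.0-fold lower number from compound 1 to compound 4 (0.30 log units; within the scatter), so at this position the chain and the ring cannot be told apart. Compound 2 also carries a ring with an amino group, but attached through a sulfonyl on an aromatic carbon, and the comparison reads a 2.0-fold higher number from compound 2 to compound 4 (0.30 log units; within the scatter), so compound 4 cannot be told apart from compound 2 either, although compound 1 and compound 2 do differ beyond the scatter. Nothing available here explains these readings.

The compounds shown leave open what happens in this assay when a hydroxyl or a carboxylic acid takes the place of the amino group on the cyclohexyl ring. They also leave open whether the other arrangement of the ring's defined stereocentres reads the same.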